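Adding a Methoxy Group to a Two-Compound Starting Point

The compounds below may be only part of what the source reports. "The series", "measured", "known", "first", "only" and "open" are said of these compounds alone.

For the measured compounds named here, compound 1 `CC(=O)N1N=C(c2ccc(OCc3cn(Cc4ccc([N+](=O)[O-])cc4)nn3)cc2)CC1c1ccccc1` is one of two compounds measured so far. In a functional assay on COLO 205 cells (Homo sapiens) for inhibition, read by sulforhodamine B assay, tested at 10 uM (on this read-out higher numbers stand for more inhibition of growth at the one concentration tested and lower numbers for less inhibition of growth), compound 1 gives 18%. The other measured compound, compound 2 `COc1cc(C2CC(c3ccc(OCc4cn(Cc5ccc([N+](=O)[O-])cc5)nn4)cc3)=NN2C(C)=O)ccc1Oc1cn(Cc2ccc([N+](=O)[O-])cc2)nn1`, gives 27% in this assay; compound 1 stands nearest to compound 2, and the gap between their two numbers lies within the usual scatter of this kind of measurement, so no order can be read from them.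

Compound 3 `COc1ccc(C2CC(c3ccc(OCc4cn(Cc5ccc([N+](=O)[O-])cc5)nn4)cc3)=NN2C(C)=O)cc1` has not been measured. It differs from compound 1 by methoxy in place of hydrogen on an aromatic carbon. Going by the values given here, no pair of measured compounds shows this kind of change, so there is no measured step to lean on. The expected step in this assay from compound 1 to compound 3 is a number 4 percentage points higher from compound 1 to compound 3 (within the scatter), which is no change beyond the scatter. For compound 3 the estimated value in this assay is 22%, expected between 8% and 38%.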

Compound 3, percent growth inhibition at one concentration: 4%
Estimate against measurement, compound 3: 18 percentage points above; the measured number lies below the stated range.
By their numbers in this assay, from the lowest: compound 3; then compounds 1 and 2 (each within the scatter of the next).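

In this assay, for the compounds shown here, methoxy in place of hydrogen on the six-membered aromatic ring of carbon only, para to a large group, gives a number 14 percentage points lower from compound 1 to compound 3 (beyond the scatter) and so provides the first measured step in this set. Until now the two measured compounds could not be placed in any order, whereas this change, phenyl to 4-methoxyphenyl, moves the read-out by more than the scatter and in the direction of less inhibition of growth. This shows that the position is not indifferent to substitution, although nothing available here explains the fall.

This single step leaves open whether the fall belongs to methoxy itself or would also follow from another group at the same place, such as hydroxy, ethoxy, fluorine or a dimethylamino group. It also leaves open whether the same change would have a similar effect on another position of this ring.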